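Saturated oxygen rings on a sulfonamide nitrogen chain

The compounds below may be only part of what the source reports. "The series", "measured", "known", "first", "only" and "open" are said of these compounds alone.

compound 1 `NC(=O)[C@@H](CCC(F)(F)F)N(CC1COC1)S(=O)(=O)c1ccc(Cl)cc1`: 2.5
compound 2 `NC(=O)[C@@H](CCC(F)(F)F)N(C[C@@H]1CCCOC1)S(=O)(=O)c1ccc(Cl)cc1`: 3.7
compound 3 `NC(=O)[C@@H](CCC(F)(F)F)N(C[C@@H]1COCCO1)S(=O)(=O)c1ccc(Cl)cc1`: 2.75

In a physicochemical assay for lipophilicity, read by HPLC, measured as octanol-water partition, at pH 7.4 (a higher number here means a more lipophilic compound, a lower number a more polar compound), compound 3 gives 2.75, second of the three numbers, with a number 0.25 log units higher from compound 1 to compound 3 (within the scatter) and a number 0.95 log units lower from compound 2 to compound 3 (beyond the scatter). Compound 4 `NC(=O)[C@@H](CCC(F)(F)F)N(C[C@@H]1CCCO1)S(=O)(=O)c1ccc(Cl)cc1` is not yet measured. The change to it is oxolan-2-yl in place of 1,4-dioxan-2-yl on a saturated chain carbon bound to a sulfonamide nitrogen. Within the data shown here, no measured step makes this exact swap. Among the measured compounds shown here, two steps bear on it: the modest a number 0.95 log units lower from compound 2 to compound 3 (beyond the scatter), which this change partly reverses in kind, and the large a number 1.20 log units higher from compound 1 to compound 2 (beyond the scatter), between two rings of different size. An upward step of modest size is expected, a number 0.45 log units higher from compound 3 to compound 4 (beyond the scatter). Compound 4 is estimated at 3.2, with an expected range from 2.85 to 3.55.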

Compound 4, distribution coefficient: 3.5
Compound 4: the middle estimate sits 0.30 log units below what was measured; the measured number falls inside the stated range.
By their numbers in this assay, from the lowest: compounds 1 and 3 (each within the scatter of the next); then compounds 4 and 2 (each within the scatter of the next).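

In this assay, the oxolan-2-yl ring separates clearly from 1,4-dioxan-2-yl at this position, with a number 0.75 log units higher from compound 3 to compound 4 (beyond the scatter), and from oxetan-3-yl, with a number 1.00 log units higher from compound 1 to compound 4 (beyond the scatter), while a number 0.20 log units lower from compound 2 to compound 4 (within the scatter) leaves it level with oxan-3-yl. Compounds 2, 3 and 4 would fit a reading by the number of ring oxygens, but compound 1 goes against it, as its single-oxygen oxetan-3-yl ring stays within the scatter of compound 3. Nothing available explains these steps. Going by these compounds, how an amine in place of the ring oxygen would read in this assay remains open.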